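This account rests on a few compounds, and the source may have more. Where it says the series, first, only, none or still open, it means among the compounds named here.

Measured so far:
- compound 1 `C[C@H](NC(=S)Nc1cc(C(F)(F)F)cc(C(F)(F)F)c1)c1nc2ccccc2[nH]1`: 220000 nM
- compound 2 `CC(C)C[C@H](NC(=S)Nc1cc(C(F)(F)F)cc(C(F)(F)F)c1)c1nc2ccccc2[nH]1`: 17400 nM

Compound 1 and compound 2 were tested in a functional assay on A549 cells (Homo sapiens) for cytotoxicity, read by MTT assay; on this read-out lower numbers stand for stronger inhibition and higher numbers for weaker inhibition. Compound 1 gives 220000 nM, which is the higher of the two numbers and so the weaker inhibition. Among the compounds with values here, the one step recorded among the measured pair runs a 13-fold lower number from compound 1 to compound 2 (1.10 log units; beyond the scatter); it changes a group on the saturated chain carbon and has nothing to do with how that carbon is drawn in space.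

Compound 3 `C[C@@H](NC(=S)Nc1cc(C(F)(F)F)cc(C(F)(F)F)c1)c1nc2ccccc2[nH]1` is the companion to compound 1 in which only the drawing of that stereocentre is changed: the two compounds have the same atoms and bonds and differ only in configuration as drawn: 1 of 1 stereo elements differ; a stereocentre at a saturated chain carbon is drawn S in compound 1 and R in compound 3. Within the data shown here, no measured step here shows what such a mirror-image change does in this assay, so the step from compound 1 to compound 2 offers no guide, and the expectation rests on the shared atoms alone. The estimate for compound 3 is therefore a step of no change at the digits printed from compound 1 to compound 3 (within the scatter), that is, no change beyond the scatter, with a wide range to allow for either direction. Compound 3 is expected to give about 220000 nM, between 60000 nM and 800000 nM.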

Compound 3, half-maximal inhibitory concentration: 15200 nM
Compound 3: the middle estimate sits 14-fold (1.16 log units) above what was measured, outside the stated range (below it).
By their numbers in this assay, from the lowest: compounds 3 and 2 (each within the scatter of the next); then compound 1.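

In this assay, the mirror-image change at the saturated chain carbon is a large one on its own, with a 14-fold lower number from compound 1 to compound 3 (1.16 log units; beyond the scatter). Within the data shown here, until now, the only change seen at this carbon was a change of group, with a 13-fold lower number from compound 1 to compound 2 (1.10 log units; beyond the scatter); this result shows that the number can also move with no atom added or removed, so the spatial arrangement at this position matters in this assay. The gap can be placed on the configuration at this one carbon and on nothing else in the structure, because no other difference separates the pair: the fact that compounds 1 and 3 differ only in the configuration as drawn

On these data alone, what remains open is whether the same mirror-image change has a similar effect when this carbon carries the larger chain of compound 2, since a single pair of mirror images gives no general rule. It is also unclear how a phenyl ring or a longer chain at this carbon would behave in either configuration, or whether a carboxylic acid elsewhere on the shared core would alter the difference between the two mirror forms.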